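Compound 2 and the loss of its trihydroxyphenyl group

This account rests on a few compounds, and the source may have more. Where it says the series, first, only, none or still open, it means among the compounds named here.

Measured in a functional assay on DU-145 cells (Homo sapiens) for inhibition, read by trypan blue exclusion, with a stated time of 96 h; on this read-out lower numbers stand for stronger inhibition of growth and higher numbers for weaker inhibition of growth:
- Compound 1 `O=C(/C(=C\c1c(O)cc(O)cc1O)S(=O)(=O)c1ccccc1Br)c1ccc(Br)cc1`: 50000 nM
- Compound 2 `Cc1ccc(S(=O)(=O)/C(=C/c2c(O)cc(O)cc2O)C(=O)c2ccc(Br)cc2)cc1`: > 100000 nM (a limit)
- Compound 3 `O=C(/C(=C\c1c(O)cc(O)cc1O)Sc1ccccc1Br)c1ccc(Cl)cc1`: > 100000 nM (a limit)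

Compound 2 has no number, only a limit, > 100000 nM. Compound 3 is held at a limit as well, so the series is marked by the limit of > 100000 nM in this assay, at which 2 of the 3 values shown sit.

The next compound is compound 4 `Cc1ccc(S(=O)(=O)/C(=C/c2ccc(F)cc2F)C(=O)c2ccc(Br)cc2)cc1`, and it differs from compound 2 in one place: 2,4-difluorophenyl in place of 2,4,6-trihydroxyphenyl on a double-bonded chain carbon bound to a double-bonded chain carbon. Among the compounds with values here, no measured step touches this group. Within the data shown here, the only step available, an at least 2.0-fold higher number from compound 1 to compound 2 (0.30 log units; that floor lies within the scatter), concerns the aryl group on the sulfonyl sulfur, so it offers no size for the present change.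

The expectation therefore rests on little. Compound 2, with its limit of > 100000 nM, leaves room for movement only toward lower numbers. A shift in that direction is expected, of uncertain size, and compound 4 may also end at the limit. The expected step in this assay is an at least 2.0-fold lower number from compound 2 to compound 4 (0.30 log units; that floor lies within the scatter). For compound 4 the estimated value is 50000 nM, with an expected range from 8000 nM to 200000 nM.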

Compound 4, concentration for 50% growth inhibition: > 100000 nM
Compound 4 gave a limit, no number; the forecaster's own chance of this, stated with the estimate: 40%; at least 2.0-fold (0.30 log units) between middle value and limit.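

Compound 2 and compound 4 both stand at a limit in this assay and not at a number, so no step can be read between them. The compounds shown leave open whether 2,4-difluorophenyl or 2,4,6-trihydroxyphenyl goes with the stronger inhibition of growth, and most values gather at one mark: the limit of > 100000 nM in this assay, at which 3 of the 4 values shown sit.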